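A few compounds are considered here, and "the series" means these few. Any claim that something is new, unique, unknown or untested is made for them only; others in the source may bear on it.

Measured so far in an assay on HEK293 cells for inhibition of Voltage-dependent T-type calcium channel subunit alpha-1G (Homo sapiens); on this read-out lower numbers stand for stronger inhibition and higher numbers for weaker inhibition:

- compound 1, `COC(=O)CC1c2ccccc2N=C(NCCCCCNC(=O)OC(C)(C)C)N1c1ccc(-c2ccccc2)cc1`: 680 nM
- compound 2, `COC(=O)CC1c2ccccc2N=C(Nc2ccc(-c3ccccc3)cc2)N1CCCCCN`: 300 nM
- compound 3, `CC(C)(C)OC(=O)NCCCCCNC1=Nc2ccccc2C(CC(=O)NCc2ccccc2)N1c1ccc(-c2ccccc2)cc1`: 160 nM

Compound 1 and compound 3 share one core and differ in a single place. The change is benzylamino in place of methoxy on a carbonyl carbon and it gave a 4.3-fold lower number from compound 1 to compound 3 (0.63 log units; beyond the scatter). Compound 2 carries a different core; the difference between the two cores is not broken down here. In this assay compound 2 stands with compound 3 within the scatter, while against compound 1 the gap is beyond the scatter.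

Compound 4, `NCCCCCN1C(Nc2ccc(-c3ccccc3)cc2)=Nc2ccccc2C1CC(=O)NCc1ccccc1`, has not yet been measured. It is built from compound 2 by the same change that turned compound 1 into compound 3: benzylamino in place of methoxy on a carbonyl carbon. The place lines read the same word for word in both pairs, so this is the same change on a different core. Among the compounds with values here, the only precedent for it is the single step from compound 1 to compound 3; whether it carries over onto the core of compound 2 cannot be read from the measured compounds. The step from compound 2 to compound 4 is therefore expected at a 3.3-fold lower number from compound 2 to compound 4 (0.52 log units; beyond the scatter), taken as a somewhat softened version of the earlier step because that one rests on one pair only, a 4.3-fold lower number from compound 1 to compound 3 (0.63 log units; beyond the scatter). Compound 4 is accordingly estimated at 90 nM in this assay, with the range 35 nM to 250 nM allowing for the change to carry over fully or only in part.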

Compound 4, half-maximal inhibitory concentration: 140 nM
Estimate against measurement, compound 4: 1.6-fold (0.19 log units) below; the range from low to high includes it.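

Working notes on the series: in this assay, benzylamino in place of methoxy on a carbonyl carbon also lowers the number on the core of compound 2, with a 2.1-fold lower number from compound 2 to compound 4 (0.33 log units; beyond the scatter), so the change acts in the same direction on both cores shown. Within the data shown here, this rests on only two pairs and does not show that the change would carry over to any further core, nor does it separate the size of the step on one core from that on the other. The two steps are therefore best read as not distinguishable in size, and the smaller number for the second step is no evidence of a weaker effect on that core: the same change on two cores in this assay, a 4.3-fold lower number (0.63 log units; beyond the scatter) from compound 1 to compound 3 and a 2.1-fold lower number (0.33 log units; beyond the scatter) from compound 2 to compound 4, 2.0-fold (0.30 log units) apart, within the scatter of two such steps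

Going by these compounds, only methoxy and benzylamino appear on this carbonyl carbon, so it remains open whether the lower number goes with the aromatic ring or the amide hydrogen, a question that methylamino or a carboxylic acid in the same place could help to answer. Among these compounds, also open is whether the step keeps its direction with a shorter or longer chain in place of the one carried by these compounds.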